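Difluorobenzyl for methylbenzyl on the piperidine-linked hydroxamate series

The source may report more compounds than this note shows. Statements on the series, on what has been measured and on what is new or still open speak of the compounds shown alone.

Of the compounds shown here, three have been measured in an assay on isolated protein for inhibition of protein deacetylase HDAC6 (Homo sapiens), read by fluorescence, with a stated time of 1 h, tested at 100 nM; a lower number here means less inhibition, a higher number more inhibition at the concentration tested (going by the name of the read-out). Compound 1 `Cc1ccc(CN2CCC(c3noc(COc4ccc(/C=C/C(=O)NO)cc4)n3)CC2)cc1` gives 76% in this assay. Compound 2 `CN(Cc1nc(C2CCN(Cc3ccccc3)CC2)no1)c1ncc(/C=C/C(=O)NO)cn1` gives 55%, and compound 3 `Cc1cccc(CN2CCC(c3noc(CN(C)c4ncc(C(=O)NO)cn4)n3)CC2)c1` gives 54%. On these numbers compound 3 holds the lowest of the three: its gap to compound 2 is within the scatter, while compound 1 stands beyond the scatter above it.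

The next compound, compound 4 `CN(Cc1nc(C2CCN(Cc3ccc(F)cc3F)CC2)no1)c1ncc(C(=O)NO)cn1`, differs from compound 3 in one place: 2,4-difluorophenyl in place of 3-methylphenyl on a saturated chain carbon bound to an amine nitrogen in a ring. Among the compounds with values here, no measured pair isolates this kind of exchange on the saturated chain carbon bound to the ring amine nitrogen, so nothing among the measured compounds indicates a shift in either direction; the step of no change at the digits printed from compound 3 to compound 4 (within the scatter) is expected to stay within the scatter. For compound 4 the value in this assay is estimated at 54%, with the range 40% to 68%.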

Compound 4, a percentage reported as inhibition, at one concentration (the size of the read-out at that concentration, not a potency): 66%
Compound 4: middle estimate off by 12 percentage points, on the low side; the measured number falls inside the stated range.
By their numbers in this assay, from the lowest: compounds 3 and 2 (each within the scatter of the next); then compounds 4 and 1 (each within the scatter of the next).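

In this assay, within the data shown here, the exchange of 3-methylphenyl for 2,4-difluorophenyl on a saturated chain carbon bound to an amine nitrogen in a ring gives a number 12 percentage points higher from compound 3 to compound 4 (beyond the scatter) and is the first single-place step, showing that the number responds to the group carried at this position. The methyl leaves and the two fluorines enter in the same step, so this pair cannot assign the shift to either one alone. Nothing available bears on why the number moves.

On these data alone, whether the same exchange carries over to the cores of compound 1 and compound 2 remains open. Also open, as far as these compounds go, is how this position responds to other groups, such as 4-fluorophenyl, unsubstituted phenyl, a pyridine ring or a cyclohexyl ring.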